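Halogenated cinnamate esters: aryl halide exchange in the whole-animal test

A few compounds are considered here, and "the series" means these few. Any claim that something is new, unique, unknown or untested is made for them only; others in the source may bear on it.

Three compounds of the series carry one shared core: compound 1 `COc1cc(OC)c(OC)cc1/C=C/COC(=O)/C=C/c1c(OC)ccc(OC)c1OC`, compound 2 `COc1cc(OC)c(OC)cc1/C=C/COC(=O)/C=C/c1cccc(Br)c1` and compound 3 `COc1cc(OC)c(OC)cc1/C=C/COC(=O)/C=C/c1cc(OC)c(OC)c(OC)c1OC`. In a functional assay on the whole organism (strain Kunming) with Mus musculus as the target, with a stated time of 0.5 h, at a dose of 100 mg/kg by the intraperitoneal route (a lower number here means a stronger effect, a higher number a weaker effect of the compound at the dose given), compound 1 gives 100%, compound 2 gives 100% and compound 3 gives 75%. Compound 2 stands level with compound 1 at the digits shown, the two together the highest numbers of the set; compound 3 lies furthest from compound 2, a gap beyond the scatter.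

Compound 4 `COc1cc(OC)c(OC)cc1/C=C/COC(=O)/C=C/c1ccccc1Cl` has not been measured. It differs from compound 2 by 2-chlorophenyl in place of 3-bromophenyl on a double-bonded chain carbon bound to a double-bonded chain carbon. For the measured compounds named here, no step between measured compounds runs through this change, and compound 2 is the only measured member bearing a halogen on that ring, so the data give no direct guide. The expected step of a number 5 percentage points lower from compound 2 to compound 4 (within the scatter) is none beyond the scatter. Compound 4 is therefore estimated at 95%, within 75% to 100%.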

Compound 4, a percentage reported as activity, at one dose (the size of the read-out at that dose, not a potency): 100%
Compound 4: middle estimate off by 5 percentage points, on the low side, and the stated range covers the measured number.
By their numbers in this assay, from the lowest: compound 3; then compounds 1, 2 and 4 (each within the scatter of the next).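

In this assay, 2-chlorophenyl in place of 3-bromophenyl on a double-bonded chain carbon bound to a double-bonded chain carbon gives no change at the digits printed from compound 2 to compound 4 (within the scatter). For the compounds shown here, this is the first step that can be read at this position, and it shows that this exchange leaves the read-out unmoved at this dose. The halogen and its place on the ring change together in this step, so neither can be read alone.

Going by these compounds, whether an amine or a carboxylic acid on that ring would move the read-out away from the level of compound 2 and compound 4 remains open. No measured property bears on this result.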